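Cathepsin S Nitrile Series: Aryl Urea Extension

A few compounds are considered here, and "the series" means these few. Any claim that something is new, unique, unknown or untested is made for them only; others in the source may bear on it.

Compound 2 `CC(C)C[C@H](NC(=O)Nc1ccccc1)C(=O)N(C)N(C)C#N` gives 0.16 nM in an assay on isolated protein for inhibition of cathepsin S (Homo sapiens), read by spectrophotometry, with a stated time of 30 min (a lower number here means a stronger inhibitor, a higher number a weaker inhibitor), the lowest of the two numbers shown; compound 1 `CN(C#N)N(C)C(=O)[C@H](CC1CCCCC1)NC(=O)OCc1ccccc1` gives 0.2 nM in this assay, and the two lie within the scatter of each other. Compound 3 `Cc1nc(-c2ccc(NC(=O)N[C@@H](CC(C)C)C(=O)N(C)N(C)C#N)cc2)no1` differs from compound 2 by 5-methyl-1,2,4-oxadiazol-3-yl in place of hydrogen on an aromatic carbon. Among the measured compounds shown here, no measured pair shows this change, so the size of the step is open; nothing beyond the scatter is expected, a slight lowering at most. Compound 3 is expected to give 0.15 nM in this assay, between 0.05 nM and 0.5 nM. The expected step is a 1.1-fold lower number from compound 2 to compound 3 (0.03 log units; within the scatter).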

Compound 3, inhibition constant: 0.19 nM
Compound 3: middle estimate off by 1.3-fold (0.10 log units), on the low side, within the range that was stated.
By their numbers in this assay, from the lowest: compounds 2, 3 and 1 (each within the scatter of the next).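

In this assay, the aromatic carbon para to a large group accepts 5-methyl-1,2,4-oxadiazol-3-yl in place of hydrogen, with a 1.2-fold higher number from compound 2 to compound 3 (0.07 log units; within the scatter). Among the compounds shown here, this is the first single-place change available, and it shows that a five-membered aromatic ring with 3 hetero atoms can stand at this position without a step beyond the scatter.

On these data alone, whether an amine, a carboxylic acid or a methoxy group at the same carbon would also stay within the scatter remains open. No measurement available bears on the reason for the size of this step.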